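This account rests on a few compounds, and the source may have more. Where it says the series, first, only, none or still open, it means among the compounds named here.

Of the compounds shown here, three built on one shared core have been measured in an assay on CHO cells for displacement of a labelled ligand from transient receptor potential cation channel subfamily V member 1 (Rattus norvegicus), read by scintillation counting, with a stated time of 60 min; on this read-out lower numbers stand for stronger inhibition and higher numbers for weaker inhibition. Compound 1 `CC(C(=O)NCc1ccc(C(C)(C)C)cc1)c1ccc(NS(C)(=O)=O)cc1` gives 106 nM, compound 2 `CC(C(=O)NCc1ccc(C(C)(C)C)cc1)c1ccc(NS(C)(=O)=O)c(I)c1` gives 23.3 nM, and compound 3 `CC(C(=O)NCc1ccc(C(C)(C)C)cc1)c1ccc(NS(C)(=O)=O)c(N2CCN(C(=O)OC(C)(C)C)CC2)c1` gives 7000 nM. Compound 2 thus stands lowest of the three, with compound 1 nearest and compound 3 furthest away. Compound 4 `Cc1cc(C(C)C(=O)NCc2ccc(C(C)(C)C)cc2)ccc1NS(C)(=O)=O` differs from compound 2 by methyl in place of iodo on an aromatic carbon. Among the compounds with values here, the only measured change at this position is a 4.5-fold lower number from compound 1 to compound 2 (0.66 log units; beyond the scatter), a modest step beyond the scatter. Because that step a 4.5-fold lower number from compound 1 to compound 2 (0.66 log units; beyond the scatter) came from adding iodo, and methyl is a different small group at the same carbon, a step of a 2.1-fold higher number from compound 2 to compound 4 (0.33 log units; beyond the scatter) is expected, landing between the values of compound 1 and compound 2. Compound 4 is estimated at 50 nM, within a range from 20 nM to 150 nM.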

Compound 4, inhibition constant: 32.8 nM
Compound 4: the middle estimate sits 1.5-fold (0.18 log units) above what was measured; the measured number falls inside the stated range.
By their numbers in this assay, from the lowest: compounds 2 and 4 (each within the scatter of the next); then compound 1; then compound 3.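

Putting methyl in place of iodo at this carbon, ortho to a methanesulfonamido group, makes no clear difference, with a 1.4-fold higher number from compound 2 to compound 4 (0.15 log units; within the scatter). Measured against hydrogen, methyl also helps, with a 3.2-fold lower number from compound 1 to compound 4 (0.51 log units; beyond the scatter), so the gain at this carbon does not depend on iodo alone, although compound 3, at 7000 nM, goes against this pattern. No measurement shown here bears on the reason for this result. As far as these compounds go, whether a chloro, a methoxy or a small amine at this carbon would also give a low number remains open.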